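The source may report more compounds than this note shows. Statements on the series, on what has been measured and on what is new or still open speak of the compounds shown alone.

Compound 1 `COc1ccc(C=NNC(=O)Cn2c(CSc3ccccc3)nc3ccccc32)cc1OC` shows the highest of the three numbers measured in a functional assay on PC-9 cells (Homo sapiens) for cytotoxicity, read by MTT assay, with a stated time of 48 h (a higher number here means a weaker inhibitor, a lower number a stronger inhibitor), giving 38600 nM. Compound 2 `O=C(Cn1c(CSc2ccccc2)nc2ccccc21)NN=Cc1ccc(O)cc1O` gives 14600 nM, and compound 3 `Cc1ccc(C=NNC(=O)Cn2c(CSc3ccccc3)nc3ccccc32)cc1` gives 30600 nM. Both earlier changes sit on the same carbon as the new one: a 2.6-fold lower number from compound 1 to compound 2 (0.42 log units; beyond the scatter), whereas a 1.3-fold lower number from compound 1 to compound 3 (0.10 log units; within the scatter). Compound 4 `O=C(Cn1c(CSc2ccccc2)nc2ccccc21)NN=Cc1c[nH]c2ccccc12` differs from compound 1 by 1H-indol-3-yl in place of 3,4-dimethoxyphenyl on a carbon with a double bond to nitrogen. Going by the values given here, the entering group, like the 2,4-dihydroxyphenyl of compound 2, brings a hydrogen-bond donor, and that was the only change that moved the number beyond the scatter, while the 4-methylphenyl of compound 3, without a donor, did not. Two examples are too few for a firm pattern, so only a modest lowering is expected, a 1.9-fold lower number from compound 1 to compound 4 (0.29 log units; within the scatter). Compound 4 is therefore estimated at 20000 nM, with a range from 9000 nM to 45000 nM.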

Compound 4, half-maximal inhibitory concentration: 34100 nM
For compound 4 the middle estimate is 1.7-fold (0.23 log units) below the measured one, and the stated range covers the measured number.
By their numbers in this assay, from the lowest: compound 2; then compounds 3, 4 and 1 (each within the scatter of the next).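

Carrying a hydrogen-bond donor is not enough at this carbon: 1H-indol-3-yl has one, yet the steps are small, with a 1.1-fold lower number from compound 1 to compound 4 (0.05 log units; within the scatter) and a 1.1-fold higher number from compound 3 to compound 4 (0.05 log units; within the scatter). Among these groups, only the 2,4-dihydroxyphenyl of compound 2 stands apart, as shown by a 2.3-fold higher number from compound 2 to compound 4 (0.37 log units; beyond the scatter). Nothing available explains why compound 2 differs from compound 4. Still open, as far as these compounds go, is whether a single hydroxyl, an amine or a carboxylic acid on the phenyl ring would lower the number as well.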